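Methoxy on the Indole Ring: Selenium and Nitro Chalcones

The source may report more compounds than this note shows. Statements on the series, on what has been measured and on what is new or still open speak of the compounds shown alone.

The three measured compounds share an indole-bearing enone linked to a trimethoxyphenyl-like ketone. Compound 1 `COc1ccc2c(/C=C(\C)C(=O)c3cc(OC)c(OC)c([Se]C)c3)cn(C)c2c1` carries a methylselanyl group and a methoxy on the indole, compound 3 `COc1cc(C(=O)/C(C)=C/c2cn(C)c3ccccc23)cc([Se]C)c1OC` carries the same methylselanyl group without that methoxy, and compound 2 `COc1cc(C(=O)/C=C/c2cn(C)c3ccccc23)cc([N+](=O)[O-])c1OC` carries a nitro group instead and also lacks the extra methoxy. In a functional assay on MHCC97H cells (Homo sapiens) for antiproliferative activity, read by MTT assay, with a stated time of 48 h (on this read-out higher numbers stand for weaker inhibition and lower numbers for stronger inhibition), compound 1 gives 15 nM, compound 3 gives 26 nM and compound 2 gives 850 nM. Compound 2 stands furthest from the other two, and the difference between the core of compound 2 and the core of compound 3 is not broken down here.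

Compound 4 `COc1ccc2c(/C=C/C(=O)c3cc(OC)c(OC)c([N+](=O)[O-])c3)cn(C)c2c1` is not yet measured. It is made from compound 2 by one change, (methoxy in place of hydrogen on an aromatic carbon), and this is the same kind of change that turns compound 3 into compound 1, (methoxy in place of hydrogen on an aromatic carbon). That earlier step is a 1.7-fold lower number from compound 3 to compound 1 (0.24 log units; within the scatter).

Because the step from compound 3 to compound 1 a 1.7-fold lower number from compound 3 to compound 1 (0.24 log units; within the scatter) is small, the expected step from compound 2 to compound 4 in this assay is also small, a 1.5-fold lower number from compound 2 to compound 4 (0.19 log units; within the scatter). Compound 4 is thus expected to give about 550 nM. Compound 4 is estimated to fall between 250 nM and 1500 nM.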

Compound 4, half-maximal inhibitory concentration: 562 nM
The estimate for compound 4 lay 1.0-fold (0.01 log units) below the measured number; low and high end bracket the measured number.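

In this assay, methoxy in place of hydrogen on an aromatic carbon gives a 1.5-fold lower number from compound 2 to compound 4 (0.18 log units; within the scatter), and the step matches the one seen earlier on the other core: the same change on two cores in this assay, a 1.7-fold lower number (0.24 log units; within the scatter) from compound 3 to compound 1 and a 1.5-fold lower number (0.18 log units; within the scatter) from compound 2 to compound 4, 1.1-fold (0.06 log units) apart, within the scatter of two such steps. The change therefore carries across these two cores without a detectable difference, even though the cores differ from each other in more than one place and their numbers lie far apart. This does not show that the methoxy itself does anything to the read-out, since each step lies within the scatter, and two pairs cannot establish that the same result would hold on any further core in the series.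

The compounds shown leave open whether a different group at this same place on the aromatic ring, such as an amine, a carboxylic acid or a longer chain, would give a step beyond the scatter. Going by these compounds alone, they also contain no pair that differs only in the nitro group against the methylselanyl group, so what separates the core of compound 2 from the core of compound 3 remains unresolved.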